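Bromo in place of ethyl on compound 2

A few compounds are considered here, and "the series" means these few. Any claim that something is new, unique, unknown or untested is made for them only; others in the source may bear on it.

compound 1 `COc1ccc(CNc2cc(OC)c(OC)c(OC)c2)cc1[N+](=O)[O-]` gives 16800 nM
compound 2 `CCC/C=C/C(=O)N(Cc1ccc(OC)c(O)c1)c1cc(OC)c(OC)c(OC)c1` gives 57 nM
compound 3 `C/C=C/C(=O)N(Cc1ccc(OC)cc1)c1cc(OC)c(OC)c(OC)c1` gives 420 nM

All three values come from a functional assay on KYSE-450 cells (Homo sapiens) for inhibition, read by MTT assay, with a stated time of 48 h (on this read-out lower numbers stand for stronger inhibition and higher numbers for weaker inhibition), and they span a wide range. Compound 2 at 57 nM has the lowest number of the three. It lies below compound 3 at 420 nM and further below compound 1 at 16800 nM and both gaps go beyond the scatter.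

Compound 4 `COc1ccc(CN(C(=O)/C=C/CBr)c2cc(OC)c(OC)c(OC)c2)cc1O` has not yet been measured. The change from compound 2 is bromo in place of ethyl on a saturated chain carbon bound to a double-bonded chain carbon and it amounts to bromo in place of ethyl on a saturated chain carbon bound to a double-bonded chain carbon. Among the measured compounds shown here, no measured pair of compounds isolates a change of this kind, so the data give no direct size for it, and compound 2 remains the nearest guide. In this assay the expected step of a 1.4-fold lower number from compound 2 to compound 4 (0.15 log units; within the scatter) is none beyond the scatter, although this rests on little evidence. For compound 4 the estimated value is 40 nM with an expected range from 8 nM to 200 nM for the coming measurement.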

Compound 4, half-maximal inhibitory concentration: 100 nM
Estimate against measurement, compound 4: 2.5-fold (0.40 log units) below; measured number inside the range.
By their numbers in this assay, from the lowest: compounds 2 and 4 (each within the scatter of the next); then compound 3; then compound 1.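

In this assay, bromo in place of ethyl on a saturated chain carbon bound to a double-bonded chain carbon gives a 1.8-fold higher number from compound 2 to compound 4 (0.24 log units; within the scatter) and so supplies the first measured size for a change at this place. The (pent-1-en-1-yl)carbonyl and (3-bromoprop-1-en-1-yl)carbonyl groups are therefore not told apart by this read-out, and this one exchange leaves the number of compound 2 within the scatter. Nothing available here bears on why the two numbers lie so close.

Compound 3 differs from compound 2 and compound 4 in more than one place, so it gives no size for a change at this position. From the compounds shown here alone, how an amine, a carboxylic acid or a longer chain would read at this same carbon in this assay remains open.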